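Ring Closure and Methoxy at the Urea Terminus

A few compounds are considered here, and "the series" means these few. Any claim that something is new, unique, unknown or untested is made for them only; others in the source may bear on it.

The series shares a core in which an amide-linked bicyclic amine is carried on a methyl-substituted benzene ring, and the variable part is the group attached to a urea carbonyl. Going by the values given here, compound 1, `CCOC(=O)CNC(=O)NCc1ccc(C(=O)N2CCCCc3ccccc32)cc1C`, gives 140 nM in a functional assay on HEK293 cells for agonist activity at Vasopressin V2 receptor (Homo sapiens), read by a luciferase reporter and cAMP accumulation (a lower number here means that less compound is needed, a higher number that more compound is needed for the effect), which places it second highest of the three numbers so far. Compound 2, `Cc1cc(C(=O)N2CCCCc3ccccc32)ccc1CNC(=O)NCC(=O)N(C)C`, gives 58 nM, and compound 3, `Cc1cc(C(=O)N2CCCCc3ccccc32)ccc1CNC(=O)N1CCC[C@@H]1C(=O)N(C)C`, gives 380 nM. The step of a 2.4-fold lower number from compound 1 to compound 2 (0.38 log units; beyond the scatter) is modest, while a 2.7-fold higher number from compound 1 to compound 3 (0.43 log units; beyond the scatter) and a 6.6-fold higher number from compound 2 to compound 3 (0.82 log units; beyond the scatter) both run the other way, showing that closing the open chain into a pyrrolidine carrying the dimethylcarbamoyl group costs potency.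

Compound 4, `CO[C@@H]1C[C@@H](C(=O)N(C)C)N(C(=O)NCc2ccc(C(=O)N3CCCCc4ccccc43)cc2C)C1`, is not yet measured. Relative to compound 1 the change is 2-(dimethylcarbamoyl)-4-methoxypyrrolidin-1-yl in place of ((ethoxycarbonyl)methyl)amino on a carbonyl carbon. The step from compound 1 to compound 3 bears most directly on this, since compound 4 carries the same pyrrolidine with an added methoxy group; the step from compound 2 to compound 3 points the same way. He therefore expects a modest rise in this assay for compound 4, beyond the scatter, of about a 2.5-fold higher number from compound 1 to compound 4 (0.40 log units; beyond the scatter). His estimate for compound 4 is 350 nM, with a likely range from 120 nM to 1000 nM.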

Compound 4, half-maximal effective concentration: 4.7 nM
Compound 4: the middle estimate sits 74-fold (1.87 log units) above what was measured; measured number outside the range, below it.
By their numbers in this assay, from the lowest: compound 4; then compound 2; then compound 1; then compound 3.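

On the carbonyl carbon whose other neighbour is an amide-type nitrogen, a pyrrolidine is not in itself the liability that compound 3 suggested: with 2-(dimethylcarbamoyl)-4-methoxypyrrolidin-1-yl in place of 2-(dimethylcarbamoyl)pyrrolidin-1-yl, this assay gives an 81-fold lower number from compound 3 to compound 4 (1.91 log units; beyond the scatter), which more than reverses the earlier loss. The same group also outperforms both open chains, with a 30-fold lower number from compound 1 to compound 4 (1.47 log units; beyond the scatter) and a 12-fold lower number from compound 2 to compound 4 (1.09 log units; beyond the scatter), so compound 4 has the lowest number of the four and the outcome at this position depends strongly on what the pyrrolidine carries. No measurement is available that explains the size of these steps.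

Compound 4 has 2 defined stereocentres, and the four compounds cannot separate the contribution of the methoxy group from that of its stereochemical arrangement. They also leave open how a hydroxyl group, a fluorine atom or an ethoxy group would compare with methoxy in this pyrrolidine, and whether the low number would survive replacing the dimethylcarbamoyl group with an ethyl ester or a carboxylic acid.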